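Trading an ester-bearing chain for a nitro group

The compounds below may be only part of what the source reports. "The series", "measured", "known", "first", "only" and "open" are said of these compounds alone.

Two compounds built on one shared core have been run in a functional assay on HT-1080 cells (Homo sapiens), read by transwell migration, with a stated time of 24 h, tested at 1 uM; on this read-out lower numbers stand for a stronger effect and higher numbers for a weaker effect at the one concentration tested. Compound 1 `CC(=O)OCc1ccc2oc(=O)c(C(=O)N(C)c3ccccc3Cl)cc2c1` gives 62.8%. Compound 2 `CCCC(=O)OCc1ccc2oc(=O)c(C(=O)Oc3cccc(Br)c3)cc2c1` gives 50.5%. Of these two numbers compound 2 holds the lower one, and its distance to compound 1 lies beyond the usual scatter of such measurements, so on this read-out compound 2 counts as the stronger of the pair.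

Compound 3 `O=C(Oc1cccc(Br)c1)c1cc2cc([N+](=O)[O-])ccc2oc1=O` has not yet been measured. It differs from compound 2 in one place: nitro in place of ((propylcarbonyl)oxy)methyl on an aromatic carbon

For the measured compounds named here, no measured pair shows a swap of this kind, so the numbers gathered so far give no hint of which way the read-out should move, or by how much. On that basis the expected step is a number 4.5 percentage points higher from compound 2 to compound 3 (within the scatter), which amounts to no change beyond the scatter in either direction. Compound 3 is therefore expected to give 55% in this assay, with a plausible range from 35% to 75%.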

Compound 3, a percentage reported as activity, at one concentration (the size of the read-out at that concentration, not a potency): 35.2%
Beside the measured number, compound 3's estimate is 19.8 percentage points above it, and the stated range covers the measured number.
By their numbers in this assay, from the lowest: compound 3; then compound 2; then compound 1.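

In this assay, putting nitro in place of ((propylcarbonyl)oxy)methyl on this aromatic carbon gives a number 15.3 percentage points lower from compound 2 to compound 3 (beyond the scatter), with the rest of the molecule unchanged. For the compounds shown here, this is the first direct reading of this position: the ester-bearing chain is not required for the effect seen at the one tested concentration, and a group with far fewer heavy atoms and no ester gives a stronger result. The two groups have the same count of hydrogen-bond acceptors, so that count does not separate them, and nothing measured here explains the change.

A single swap cannot show whether the gain comes from having nitro at this carbon or simply from losing the longer chain, and an amine, a carboxylic acid or a methoxy group at the same place would help separate those two readings. Compound 1 differs from compound 3 in more than one place, so it cannot settle this, and a single concentration leaves open how the compounds would rank across a range of concentrations.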